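Methyl for vinyl on the amide aryl of compound 3

A few compounds are considered here, and "the series" means these few. Any claim that something is new, unique, unknown or untested is made for them only; others in the source may bear on it.

Measured compounds and their maximal responses in a functional assay on HEK293 cells for agonist activity at D(4) dopamine receptor (Homo sapiens), read by FLIPR; on this read-out higher numbers stand for larger maximal responses and lower numbers for smaller maximal responses:
compound 1 `Cc1cccc(C(=O)NCN2CCC(c3nccs3)CC2)c1`, 71%
compound 2 `O=C(NCN1CCC(c2cccc[n+]2[O-])CC1)c1cnccc1Cl`, 44%
compound 3 `C=Cc1cccc(C(=O)NCN2CCC(c3cccc[n+]3[O-])CC2)c1`, 63%

On these three numbers compound 3 lies within the usual scatter of compound 1 and is separated from compound 2 by a gap beyond the scatter, so it belongs with the higher pair rather than with compound 2. Going by the values given here, the only measured step is a number 19 percentage points higher from compound 2 to compound 3 (beyond the scatter), which exchanges the whole aryl group on the carbonyl carbon and so bears only loosely on the change now considered.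

Compound 4 `Cc1cccc(C(=O)NCN2CCC(c3cccc[n+]3[O-])CC2)c1` differs from compound 3 as follows: methyl in place of vinyl on an aromatic carbon. Among the compounds with values here, no measured step isolates this exchange. What the numbers show is that compound 1, carrying 3-methylphenyl on a different core, and compound 3, carrying 3-vinylphenyl, give responses within the scatter of each other in this assay. From that, no step beyond the scatter is expected for a number 3 percentage points higher from compound 3 to compound 4 (within the scatter). Compound 4 is therefore estimated at 66% in this assay, with a range from 52% to 80%.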

Compound 4, largest response reached (reported as efficacy), in percent of the reference or control that the assay uses: 77%
Compound 4: the middle estimate sits 11 percentage points below what was measured; the range from low to high includes it.
By their numbers in this assay, from the lowest: compound 2; then compounds 3, 1 and 4 (each within the scatter of the next, the first and the last beyond it).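

In this assay, going by these compounds alone, the exchange at this aromatic carbon is now isolated on a single core: methyl in place of vinyl gives a number 14 percentage points higher from compound 3 to compound 4 (beyond the scatter), so this position responds to a change that the earlier compounds could not separate from other differences. With 3-methylphenyl held, the exchange from 4-chloropyridin-3-yl on the carbonyl carbon gives a number 33 percentage points higher from compound 2 to compound 4 (beyond the scatter), whereas the exchange of groups on the saturated ring carbon gives only a number 6 percentage points higher from compound 1 to compound 4 (within the scatter), so the two groups at that site are not told apart in this comparison. No available measurement accounts for these steps.

Still open, on these data alone, is how ethyl, methoxy or an amine on this aromatic carbon would compare with methyl and vinyl. Whether the vinyl-to-methyl step also holds on the core of compound 1 is open as well.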